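Hydroxy Addition on Curcumin-like Diketones and Enones

The source may report more compounds than this note shows. Statements on the series, on what has been measured and on what is new or still open speak of the compounds shown alone.

Measured so far:
Compound 1, `O=C(/C=C/c1ccc(O)c(O)c1)CC(=O)/C=C/c1cccc(O)c1O`: 19000 nM
Compound 2, `O=C(/C=C/c1ccc(O)cc1)CC(=O)/C=C/c1cccc(O)c1O`: 27000 nM
Compound 3, `O=C(/C=C/c1cccc(O)c1)/C=C/c1ccc(O)c(O)c1`: 71000 nM

In a functional assay, with a stated time of 30 min (on this read-out lower numbers stand for stronger inhibition and higher numbers for weaker inhibition), compound 3 gives the highest of the three numbers; its nearest neighbour is compound 2, and compound 1 lies furthest from it. The difference between the core of compound 3 and the core of compound 2 is not broken down here. Between compound 2 and compound 1 the change is hydroxy in place of hydrogen on an aromatic carbon, and it made the step of a 1.4-fold lower number from compound 2 to compound 1 (0.15 log units; within the scatter). Compound 4, `O=C(/C=C/c1ccc(O)c(O)c1)/C=C/c1cc(O)ccc1O`, has not yet been measured in this assay. It differs from compound 3 by hydroxy in place of hydrogen on an aromatic carbon, the same kind of change, though the place here is ortho to a large group and para to a hydroxy group rather than ortho to a hydroxy group and meta to a large group. Because the earlier step of a 1.4-fold lower number from compound 2 to compound 1 (0.15 log units; within the scatter) stayed within the scatter, a similar small step is expected: the step from compound 3 to compound 4 is estimated as a 1.3-fold lower number from compound 3 to compound 4 (0.11 log units; within the scatter). Compound 4 is therefore expected to give about 55000 nM, somewhere between 22000 nM and 140000 nM.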

Compound 4, half-maximal inhibitory concentration: 25000 nM
Beside the measured number, compound 4's estimate is 2.2-fold (0.34 log units) above it; the measured number falls inside the stated range.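

In this assay, hydroxy in place of hydrogen on an aromatic carbon gave a 2.8-fold lower number from compound 3 to compound 4 (0.45 log units; beyond the scatter). Set beside the earlier case, the two steps cannot be told apart: the same change on two cores in this assay, a 1.4-fold lower number (0.15 log units; within the scatter) from compound 2 to compound 1 and a 2.8-fold lower number (0.45 log units; beyond the scatter) from compound 3 to compound 4, 2.0-fold (0.30 log units) apart, within the scatter of two such steps. Going by these compounds alone, this is consistent with the change carrying from one core to the other at a similar size, but it rests on only two pairs, with the hydroxy at a different place in each, and it does not establish that the step is fixed across this series.

The compounds shown leave open how a methoxy group or an amine at the same place would compare with hydroxy. They also leave open whether the step would hold on a core with a longer chain.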